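Replacing the Benzyl Ring with a Cyclopropyl Ketone

This account rests on a few compounds, and the source may have more. Where it says the series, first, only, none or still open, it means among the compounds named here.

Compound 1 `COc1ccc(-n2c(SCc3ccccc3)nnc2-c2cc(OC)c(OC)c(OC)c2)cc1` in a functional assay on HepG2 cells (Homo sapiens) for inhibition, read by MTT assay, with a stated time of 48 h (a higher number here means a weaker inhibitor, a lower number a stronger inhibitor), gives > 60000 nM.
Compound 2 `COc1ccc(-n2c(SCc3ccc(C)cc3)nnc2-c2cc(OC)c(OC)c(OC)c2)cc1` in this assay gives 31600 nM.

Compound 1 stands at the limit of > 60000 nM in this assay, at which 1 of the 2 values shown sits; its value is a limit of the assay and not a number. For the measured compounds named here, compound 2 gives a number, and the one measured step, an at least 1.8-fold lower number from compound 1 to compound 2 (0.27 log units; that floor lies within the scatter), has a floor that lies within the scatter, so it shows no change that can be trusted.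

Compound 3 `COc1ccc(-n2c(SCC(=O)C3CC3)nnc2-c2cc(OC)c(OC)c(OC)c2)cc1` differs from compound 1 at another place: cyclopropylcarbonyl in place of phenyl on a saturated chain carbon bound to a sulfur. Going by the values given here, the methyl step between compound 1 and compound 2 touched the phenyl that compound 3 no longer carries, so it does not bear on this change, and no other measured step does. Among the compounds with values here, nothing among the measured compounds therefore supports a step beyond the scatter in either direction in this assay, and a value near the limit of compound 1 is the plain expectation.

Compound 3 is accordingly estimated at 60000 nM, within 20000 nM to 200000 nM. That estimate means an expected step of a number no higher from compound 1 to compound 3 (the limit leaves the size open), with a real chance that only a limit is reported again.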

Compound 3, half-maximal inhibitory concentration: > 60000 nM
Compound 3 ended at the assay's limit (the forecaster's own chance of this, stated with the estimate: 55%); the middle value lies on the limit itself.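

Compound 3 gives > 60000 nM in this assay, which is a limit of the assay and not a number, and this is the limit where compound 1 also stands: the limit of > 60000 nM in this assay, at which 2 of the 3 values shown sit. The step between these two compounds cannot be read, so the change from phenyl to cyclopropylcarbonyl on a saturated chain carbon bound to a sulfur has no measured size. For the compounds shown here, the one readable step, an at least 1.8-fold higher number from compound 2 to compound 3 (0.27 log units; that floor lies within the scatter), has a floor within the scatter, so replacing 4-methylphenyl with cyclopropylcarbonyl shows no change that can be trusted, and compound 2 remains the only one of the three with a number.

The compounds shown leave open how far compound 1 and compound 3 actually lie from the limit, and so whether the carbonyl-bearing group differs at all from phenyl at this place. They also leave open whether another group here, such as an amine, a carboxylic acid or a longer chain, would give a number clearly beyond the scatter from that of compound 2.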